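This account rests on a few compounds, and the source may have more. Where it says the series, first, only, none or still open, it means among the compounds named here.

Measured compounds:
Compound 1 `O=C(NC[C@@H](O)C(=O)O)c1ccc(CN(C(=O)Nc2cccc(Br)c2)c2ccc(C3CCCCC3)cc2)cc1`: 216 nM in an in vitro assay on BHK cells for binding affinity to gastric inhibitory polypeptide receptor (Homo sapiens); a lower number here means a stronger inhibitor, a higher number a weaker inhibitor
Compound 2 `O=C(NC[C@@H](O)C(=O)O)c1ccc(CN(C(=O)Nc2cc(Br)cc(C(F)(F)F)c2)c2ccc(C3=CCCCC3)cc2)cc1`: 380 nM
Compound 3 `Cc1cc(NC(=O)N(Cc2ccc(C(=O)NC[C@@H](O)C(=O)O)cc2)[C@H]2CC[C@H](C(C)(C)C)CC2)cc(C(F)(F)F)c1`: 98 nM

Of these three numbers in this assay, compound 2 has the highest; compound 1 lies within the scatter of it, while compound 3, with the lower number, sits beyond the scatter. Compound 4 `O=C(NC[C@@H](O)C(=O)O)c1ccc(CN(C(=O)Nc2ccccc2)c2ccc(C3=CCCCC3)cc2)cc1` is not yet measured. It differs from compound 2 by phenyl in place of 3-bromo-5-(trifluoromethyl)phenyl on an amide-type nitrogen. Going by the values given here, no measured pair isolates this change. Every measured compound carries a substituted ring at that place, so stripping it to a bare phenyl is expected to move the number upward, beyond the scatter, by about a 2.9-fold higher number from compound 2 to compound 4 (0.46 log units; beyond the scatter). Compound 4 is therefore expected to give 1100 nM, with a range from 350 nM to 3500 nM.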

Compound 4, half-maximal inhibitory concentration: 1390 nM
Beside the measured number, compound 4's estimate is 1.3-fold (0.10 log units) below it; measured number inside the range.
By their numbers in this assay, from the lowest: compound 3; then compounds 1 and 2 (each within the scatter of the next); then compound 4.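

In this assay, phenyl in place of 3-bromo-5-(trifluoromethyl)phenyl on the amide-type nitrogen gives a 3.7-fold higher number from compound 2 to compound 4 (0.56 log units; beyond the scatter). Going by these compounds alone, this is the first comparison in which only this place changes, and it shows that the number responds to what the ring carries here. No measurement shown accounts for the shift.

Both substituents leave in one step, and the compounds shown do not divide that step between the bromine and the trifluoromethyl. On these data alone, whether a nitrile or a methoxy group on that ring would bring the number back down also remains open.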